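Swapping Chloro for Methoxy: An Unmeasured Analogue

This account rests on a few compounds, and the source may have more. Where it says the series, first, only, none or still open, it means among the compounds named here.

Compound 1 `O=c1oc(-c2ccccc2I)nc2cc(Cl)ccc12`: > 62500 nM
Compound 2 `O=c1oc(-c2ccccc2I)nc2cc(Cl)c(Cl)cc12`: > 62500 nM

Of the compounds shown here, two have been tested in an assay on isolated protein for inhibition of complement C1r subcomponent (Homo sapiens); a lower number here means a stronger inhibitor, a higher number a weaker inhibitor. In this assay compound 1 gives > 62500 nM, which is a limit of the assay and not a number. Compound 2 likewise gives > 62500 nM, again only a limit. Within the data shown here, the single measured step, a step that the two limits leave unreadable from compound 1 to compound 2, therefore cannot be read, and compound 1 stands on no number at all: both values sit at the limit of > 62500 nM in this assay, at which 2 of the 2 values shown sit.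

Compound 3 `COc1ccc2c(=O)oc(-c3ccccc3I)nc2c1` is not yet measured. It differs from compound 1 by methoxy in place of chloro on an aromatic carbon. Among the measured compounds shown here, no measured step bears on this change, since the only step available is unreadable. What can be said is that compound 1 shows no measurable inhibition at the limit reached, and a single change on an aromatic carbon gives no grounds to expect a readable value. Compound 3 is therefore expected near 100000 nM, within 30000 nM to 500000 nM. The step this estimate implies is a step that the limit leaves unreadable from compound 1 to compound 3, which is an expectation only, most likely again returning a limit.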

Compound 3, half-maximal inhibitory concentration: > 62500 nM
Compound 3: a limit, no number (the forecaster's own chance of this, stated with the estimate: 80%); the middle value lies beyond the limit too.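

Among these compounds, compound 3 also ends at a limit of the assay and not a number, so the step from compound 1 to compound 3 cannot be read and no new step emerges. All three compounds stand at the same limit: the limit of > 62500 nM in this assay, at which 3 of the 3 values shown sit. The compounds shown leave open which change to the shared core, if any, would give a readable value.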